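This account rests on a few compounds, and the source may have more. Where it says the series, first, only, none or still open, it means among the compounds named here.

Compound 1 `CC(C)N(C(=O)CN1C=CN(c2ccccc2)C(=O)C(Cc2n[nH]c3ccccc23)C1=O)c1ccc(F)cc1`: 282 nM
Compound 2 `COc1ccc(N(C(=O)CN2C=CN(c3ccccc3)C(=O)C(Cc3n[nH]c4ccccc34)(OC)C2=O)C(C)C)cc1`: 166 nM

Both compounds were run in a functional assay on CHO cells for agonist activity at Melanocortin receptor 4 (Homo sapiens), read by a luciferase reporter, with a stated time of 4 h; on this read-out lower numbers stand for an effect already at smaller amounts and higher numbers for an effect only at larger amounts of compound. Compound 1 gives 282 nM in this assay, and compound 2 gives 166 nM. Compound 2 thus stands at the lower of the two numbers, but its gap to compound 1 is within the usual scatter, so the two cannot be ranked against each other.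

Compound 3 `COC1(Cc2n[nH]c3ccccc23)C(=O)N(CC(=O)N(c2ccc(F)cc2)C(C)C)C=CN(c2ccccc2)C1=O` is the next compound, and it differs from compound 2 in one place: fluoro in place of methoxy on an aromatic carbon. Among the measured compounds shown here, no measured pair shows this change on its own. Compound 1 already carries the fluoro group on this ring, though it lacks the methoxy on the shared core, and its value sits within the scatter of that of compound 2. On that basis the step from compound 2 to compound 3 is expected to be none beyond the scatter, with at most a slight move towards a higher number, so that a 1.3-fold higher number from compound 2 to compound 3 (0.12 log units; within the scatter) is the expected size. Compound 3 is therefore estimated at 220 nM in this assay, with a likely range from 110 nM to 450 nM.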

Compound 3, half-maximal effective concentration: 44.7 nM
Beside the measured number, compound 3's estimate is 4.9-fold (0.69 log units) above it; the whole stated range lies above it.
By their numbers in this assay, from the lowest: compound 3; then compounds 2 and 1 (each within the scatter of the next).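

In this assay, the change from 4-methoxyphenyl to 4-fluorophenyl gives a 3.7-fold lower number from compound 2 to compound 3 (0.57 log units; beyond the scatter), so the group on this aromatic carbon, para to a large group, does affect the read-out when the methoxy sits on the saturated ring carbon of the shared core. The methoxy on that saturated ring carbon also matters with the fluoro group held in place: methoxy in place of hydrogen there gives a 6.3-fold lower number from compound 1 to compound 3 (0.80 log units; beyond the scatter), an effect that could not be seen earlier, since the two earlier compounds differ in two places and neither change could be read alone. The material at hand offers nothing that explains either step. 

From the compounds shown here alone, whether fluoro in place of methoxy gives a step of similar size on a core with hydrogen on the saturated ring carbon stays open, so the two changes cannot yet be called independent of each other. Also open, going by these compounds, is how the read-out would respond to a chlorine atom, a nitrile or a plain hydrogen on the aromatic carbon, or to an ethoxy or a hydroxyl group on the saturated ring carbon.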